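Dropping the Chloro Group from a Triazole Pair

A few compounds are considered here, and "the series" means these few. Any claim that something is new, unique, unknown or untested is made for them only; others in the source may bear on it.

Measured so far:
compound 1 `Clc1ccc(-n2nncc2-c2cccnc2)cc1`: 27 mg/kg
compound 2 `Clc1ccc(-n2nncc2-c2ccccn2)cc1`: 50.4 mg/kg

In a functional assay on the whole organism with Mus musculus as the target (on this read-out lower numbers stand for an effect already at smaller amounts and higher numbers for an effect only at larger amounts of compound), compound 2 gives 50.4 mg/kg, the highest of the two numbers; its nearest neighbour is compound 1 with 27 mg/kg, separated by the step of a 1.9-fold higher number from compound 1 to compound 2 (0.27 log units; within the scatter). Compound 3 `c1ccc(-n2nncc2-c2ccccn2)cc1` differs from compound 2 by hydrogen in place of chloro on an aromatic carbon. Going by the values given here, no measured step covers this change; the only step at hand, a 1.9-fold higher number from compound 1 to compound 2 (0.27 log units; within the scatter), concerns a different position and was small. With nothing pointing clearly either way, only a modest shift is expected, about a 1.3-fold higher number from compound 2 to compound 3 (0.11 log units; within the scatter). Compound 3 is therefore estimated at 65 mg/kg, with a range from 25 mg/kg to 170 mg/kg.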

Compound 3, dose for half-maximal effect: 25.6 mg/kg
For compound 3 the middle estimate is 2.5-fold (0.40 log units) above the measured one, within the range that was stated.
By their numbers in this assay, from the lowest: compounds 3, 1 and 2 (each within the scatter of the next).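

Going by these compounds alone, both earlier compounds carried chloro, so this is the first look at the shared core without it on the aromatic carbon para to a large group. In this assay, hydrogen in place of chloro gives a 2.0-fold lower number from compound 2 to compound 3 (0.29 log units; within the scatter), so the chlorine atom is not required for the effect in this pair. No supporting measurement offers an explanation for this result. Still open, on these data alone, is whether a methoxy group or an amine at this position would shift the number beyond the scatter. Also open, as far as these compounds go, is whether the pyridin-3-yl compound 1 would respond in the same way to losing its chloro.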